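Extending acetyl to propanoyl on the methoxy compound

The compounds below may be only part of what the source reports. "The series", "measured", "known", "first", "only" and "open" are said of these compounds alone.

Compound 1 `CC(=O)NNC(=O)c1csc2ncc(-c3ccc(C)cc3)n12` gives 71800 nM
Compound 2 `CCC(=O)NNC(=O)c1csc2ncc(-c3ccc(C)cc3)n12` gives 9230 nM
Compound 3 `COc1ccc(-c2cnc3scc(C(=O)NNC(C)=O)n23)cc1` gives 17000 nM

These values all come from a functional assay on HCT-116 cells (Homo sapiens) for antiproliferative activity, read by MTT assay, with a stated time of 72 h (on this read-out lower numbers stand for stronger inhibition and higher numbers for weaker inhibition), and separate compound 3 clearly from only one of the other two compounds. The measured step of a 4.2-fold lower number from compound 1 to compound 3 (0.63 log units; beyond the scatter) lies beyond the scatter, whereas the values of compound 2 and compound 3 lie within the scatter of each other.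

The next compound is compound 4 `CCC(=O)NNC(=O)c1csc2ncc(-c3ccc(OC)cc3)n12` with the difference methyl in place of hydrogen on a saturated chain carbon bound to a carbonyl carbon in its structure: methyl in place of hydrogen on a saturated chain carbon bound to a carbonyl carbon, which turns acetyl into propanoyl.

Among the compounds with values here, only one measured step makes this same change, and a 7.8-fold lower number from compound 1 to compound 2 (0.89 log units; beyond the scatter) is a modest step beyond the scatter. It was seen with methyl on the aromatic carbon, whereas compound 3 carries methoxy there. Within the data shown here, the step of a 4.2-fold lower number from compound 1 to compound 3 (0.63 log units; beyond the scatter) shows that methoxy in place of methyl was itself modest with acetyl present, and no measured pair shows how the two changes combine. A modest step to a lower number is therefore expected in this assay and may be somewhat smaller than the one measured. The expected step is a 4.9-fold lower number from compound 3 to compound 4 (0.69 log units; beyond the scatter) in size and direction. Compound 4 is estimated at 3500 nM with an expected range from 1400 nM up to 10000 nM for repeated measurements.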

Compound 4, half-maximal inhibitory concentration: 64300 nM
Estimate against measurement, compound 4: 18-fold (1.26 log units) below; the measured number lies above the stated range.
By their numbers in this assay, from the lowest: compounds 2 and 3 (each within the scatter of the next); then compounds 4 and 1 (each within the scatter of the next).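

In this assay, methyl in place of hydrogen on a saturated chain carbon bound to a carbonyl carbon now gives a 3.8-fold higher number from compound 3 to compound 4 (0.58 log units; beyond the scatter), so turning acetyl into propanoyl does not move the number in one direction on both cores: the same change on two cores in this assay, a 7.8-fold lower number (0.89 log units; beyond the scatter) from compound 1 to compound 2 and a 3.8-fold higher number (0.58 log units; beyond the scatter) from compound 3 to compound 4, 29-fold (1.47 log units) apart, beyond the scatter of two such steps

Methoxy in place of methyl on an aromatic carbon also reverses its direction once propanoyl is present, giving a 7.0-fold higher number from compound 2 to compound 4 (0.84 log units; beyond the scatter), so the outcome of this change likewise depends on the group in the other place: the same change on two cores in this assay, a 4.2-fold lower number (0.63 log units; beyond the scatter) from compound 1 to compound 3 and a 7.0-fold higher number (0.84 log units; beyond the scatter) from compound 2 to compound 4, 29-fold (1.47 log units) apart, beyond the scatter of two such steps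

Taken together, these four compounds show that the two changes do not act independently, and neither can be given a single direction on its own.

The compounds shown cover only two chain groups and two aromatic groups, so it remains open whether butanoyl in place of propanoyl would follow the trend of the methyl compounds or that of the methoxy compounds. From the compounds shown here alone, it is also open whether fluorine or hydroxyl on the same aromatic carbon would pair with acetyl and propanoyl in the same crossed way.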